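The source may report more compounds than this note shows. Statements on the series, on what has been measured and on what is new or still open speak of the compounds shown alone.

Compound 1, with the structure `CCCS(=O)(=O)Nc1cccc2c1CCCC2c1c[nH]cn1`, was examined in an assay on isolated protein (Cricetulus griseus) for binding affinity to Alpha-1B adrenergic receptor (Mesocricetus auratus), read by radioligand binding; a lower number here means a stronger inhibitor, a higher number a weaker inhibitor. For compound 1 this assay recorded only a limit of < 10000 nM, not a measured number (the limit of < 10000 nM in this assay, at which 1 of the 2 values shown sits). Going by the values given here, a second member of the same series, compound 2 with the structure `CS(=O)(=O)Nc1c(O)ccc2c1CCCC2c1c[nH]cn1`, gave a measured inhibition constant of 2510 nM in this assay; compound 2 differs from compound 1 in more than one place, so no single step between the two is drawn.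

The account now turns to compound 3, whose structure is `O=C(Nc1cccc2c1CCCC2c1c[nH]cn1)C(F)(F)F`. Its structural change from compound 1 is (trifluoromethyl)carbonyl in place of propylsulfonyl on a nitrogen on an aromatic ring. With compound 1 known only as a limit, the step from compound 1 to compound 3 cannot be measured against a number. Compound 3 is expected to land at roughly 4000 nM, with a plausible range from 800 nM to 20000 nM, and the step that the limit leaves unreadable from compound 1 to compound 3 is the expected one in this assay.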

Compound 3, inhibition constant: < 10000 nM
Compound 3 gave a limit, no number; the forecaster's own chance of this, stated with the estimate: 35%; the middle value is on the limit's open side.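

Going by these compounds alone, no step from compound 1 to compound 3 can be read, because both compounds rest on a limit and not a number: the limit of < 10000 nM in this assay, at which 2 of the 3 values shown sit. The compounds shown leave open whether (trifluoromethyl)carbonyl and propylsulfonyl on that nitrogen differ at all in this assay.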